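Chain Length and Cytotoxicity in Alkylamino Nucleosides

This account rests on a few compounds, and the source may have more. Where it says the series, first, only, none or still open, it means among the compounds named here.

Of the compounds shown here, three have so far been tested in an ADME assay on A549 cells (Homo sapiens) for cytotoxicity, read by MTT assay; on this read-out higher numbers stand for lower toxicity in this test and lower numbers for higher toxicity in this test. Compound 1, `CCCCCCCCCCCCNc1ccn([C@H]2C[C@H](O)[C@@H](CO)O2)c(=O)n1`, gives 100000 nM. Compound 2, `CCCCCCCCCCCCCCNc1ccn([C@H]2C[C@H](O)[C@@H](CO)O2)c(=O)n1`, gives 90000 nM in this assay. Compound 3, `CCCCCCCCNc1ccn([C@@H]2O[C@H](CO)[C@@H](O)[C@H]2O)c(=O)n1`, gives 90000 nM in this assay. The three numbers sit close together: a 1.1-fold lower number from compound 1 to compound 2 (0.05 log units; within the scatter), and compound 3 stands level with compound 2 at the digits given, with compound 1 at a very similar value. How the core of compound 3 differs from the core of compound 1 is not broken down here.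

Compound 4, `CCCCCCCCCCNc1ccn([C@@H]2O[C@H](CO)[C@@H](O)[C@H]2O)c(=O)n1`, has not yet been measured in this assay. It differs from compound 3 by ethyl in place of hydrogen on a saturated chain carbon, eight bonds along the chain from a nitrogen on an aromatic ring. The same kind of change separates compound 1 from compound 2, where it reads (ethyl in place of hydrogen on a saturated chain carbon, ten or more bonds along the chain from a nitrogen on an aromatic ring); the two places are not the same word for word, as the two descriptions show. In the measured pair that change made a 1.1-fold lower number from compound 1 to compound 2 (0.05 log units; within the scatter), a step within the scatter. On that basis, and on compound 3 showing 90000 nM, the step is expected to be small: no change at the digits printed from compound 3 to compound 4 (within the scatter). Compound 4 is therefore estimated at 90000 nM in this assay, with a range from 50000 nM to 160000 nM. Among the compounds with values here, only one measured pair carries this change, so the expectation rests on little.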

Compound 4, half-maximal cytotoxic concentration: 90000 nM
For compound 4 middle estimate and measured number coincide at the digits printed; low and high end bracket the measured number.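

In this assay, putting ethyl in place of hydrogen on a saturated chain carbon, eight bonds along the chain from a nitrogen on an aromatic ring, gives no change at the digits printed from compound 3 to compound 4 (within the scatter). Set beside the earlier step, the change reads alike on the two cores, so in this small set its effect on this read-out carries from one core to the other without any difference that can be told from the scatter: the same change on two cores in this assay, a 1.1-fold lower number (0.05 log units; within the scatter) from compound 1 to compound 2 and no change at the digits printed (within the scatter) from compound 3 to compound 4, 1.1-fold (0.05 log units) apart, within the scatter of two such steps This does not show that the change would read the same on any other core, since it rests on just two pairs, the change sits at different places along the chain in those pairs, and all four numbers lie close together, so a small real difference between the cores could stay hidden.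

The compounds shown leave open whether a chain longer than that of compound 2 would stay level with these numbers or move clearly away from them. They also leave open how this read-out would respond if an amine or a carboxylic acid stood on a saturated chain carbon in place of ethyl.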